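From a Pentyl Chain to a Pyridin-2-yl Ring

This account rests on a few compounds, and the source may have more. Where it says the series, first, only, none or still open, it means among the compounds named here.

Compound 1 `Nc1nc(N2CCN(C(=O)COc3ccc(Cl)cc3)CC2)c2nc(-c3ccc(F)cc3)sc2n1`: 490 nM
Compound 2 `Nc1nc(N2CCN(C(=O)COc3ccc(Cl)cc3)CC2)c2nc(Cc3ccc(F)cc3)sc2n1`: 700 nM
Compound 3 `CCCCCc1nc2c(N3CCN(C(=O)COc4ccc(Cl)cc4)CC3)nc(N)nc2s1`: 690 nM

In a functional assay on cells (Lymphocyte, Homo sapiens) (on this read-out higher numbers stand for weaker inhibition and lower numbers for stronger inhibition), compound 3 gives 690 nM, the second highest of the three numbers; its nearest neighbour is compound 2 a 1.0-fold lower number from compound 2 to compound 3 (0.01 log units; within the scatter), its furthest compound 1 a 1.4-fold higher number from compound 1 to compound 3 (0.15 log units; within the scatter), so all three sit within the scatter of one another. Compound 4 `Nc1nc(N2CCN(C(=O)COc3ccc(Cl)cc3)CC2)c2nc(-c3ccccn3)sc2n1` differs from compound 3 in one place: pyridin-2-yl in place of pentyl on an aromatic carbon. The step that bears on this is the one in which pentyl replaced 4-fluorophenyl a 1.4-fold higher number from compound 1 to compound 3 (0.15 log units; within the scatter), a change that stayed within the scatter, as did the benzyl variant a 1.4-fold higher number from compound 1 to compound 2 (0.15 log units; within the scatter). An aromatic ring returning to this aromatic carbon is therefore expected to move the number little a 1.4-fold lower number from compound 3 to compound 4 (0.14 log units; within the scatter). Compound 4 is expected to give about 500 nM, between 200 nM and 1300 nM.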

Compound 4, half-maximal inhibitory concentration: 230 nM
Compound 4: middle estimate off by 2.2-fold (0.34 log units), on the high side, and the stated range covers the measured number.
By their numbers in this assay, from the lowest: compound 4; then compounds 1, 3 and 2 (each within the scatter of the next).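

In this assay, pyridin-2-yl is the only group shown on this aromatic carbon, next to the ring nitrogen and the ring sulfur, that moves the number beyond the scatter: a 3.0-fold lower number from compound 3 to compound 4 (0.48 log units; beyond the scatter) against pentyl, a 3.0-fold lower number from compound 2 to compound 4 (0.48 log units; beyond the scatter) against 4-fluorobenzyl and a 2.1-fold lower number from compound 1 to compound 4 (0.33 log units; beyond the scatter) against 4-fluorophenyl. An aromatic ring as such is not enough, as the 4-fluorophenyl of compound 1 stays within the scatter of the pentyl of compound 3. No measured evidence accounts for this step. From the compounds shown here alone, it remains open whether a plain phenyl, pyridin-3-yl or pyridin-4-yl ring on this carbon would give a number like that of compound 4.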